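A few compounds are considered here, and "the series" means these few. Any claim that something is new, unique, unknown or untested is made for them only; others in the source may bear on it.

Measured in a functional assay on HEK293 cells for antagonist activity at Orexin receptor type 2 (Homo sapiens), read by FLIPR and calcium flux; a lower number here means a less potent compound, a higher number a more potent compound, by a factor of ten per unit of this negative logarithm:
Compound 1, `Cc1ccc(-c2ncccn2)c(C(=O)N2CC3(CC3)C[C@H]2CNc2ccc(C(F)(F)F)cn2)n1`, gives 7.5.
Compound 2, `Cc1nc(C(=O)N2CC3(CC3)C[C@H]2CNc2cc(C(F)(F)F)ccn2)c(-c2ccccc2)s1`, gives 8.5.
Compound 3, `Cc1ccc(-n2nccn2)c(C(=O)N2CCC3(CC3)C[C@H]2CNc2ccc(Cl)cn2)c1`, returns no number but only a limit, < 5; this is the limit of < 5 in this assay, at which 1 of the 3 values shown sits.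

Compound 2 stands highest of the two numbers; compound 1 sits a full step lower, beyond the scatter. Compound 4, `Cc1cc(C)nc(NC[C@@H]2CC3(CC3)CN2C(=O)c2nc(C)sc2-c2ccccc2)n1`, is not yet measured. It differs from compound 2 in one place: 4,6-dimethylpyrimidin-2-yl in place of 4-(trifluoromethyl)pyridin-2-yl on an amine nitrogen. No measured pair covers this exchange, so its direction rests on nothing shown; the step is expected to be modest, downward or none beyond the scatter, as a number 0.50 log units lower from compound 2 to compound 4 (beyond the scatter). Compound 4 is expected to give 8 in this assay, with a range from 7.2 to 8.8.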

Compound 4, negative logarithm of the antagonist equilibrium constant: 8.6
Estimate against measurement, compound 4: 0.60 log units below; low and high end bracket the measured number.
By their numbers in this assay, from the lowest: compound 1; then compounds 2 and 4 (each within the scatter of the next). At a limit, below all of these: compound 3.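

In the pair at this place on the amine nitrogen, 4,6-dimethylpyrimidin-2-yl for 4-(trifluoromethyl)pyridin-2-yl gives a number 0.10 log units higher from compound 2 to compound 4 (within the scatter) in this assay. On this core, then, trifluoromethyl is not required to hold this level of potency, and a pyrimidine ring carrying two methyl groups serves as well. Nothing shown gives a reason for this result.

Ring and substituents change together here, so the share of each stays open. Also open, going by these compounds, is how a methoxy group or an amine on that pyrimidine ring would read.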